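Lengthening the side chain of compound 3

A few compounds are considered here, and "the series" means these few. Any claim that something is new, unique, unknown or untested is made for them only; others in the source may bear on it.

Compound 1 `CN(C)CCCCn1c(N)c(-c2nc3ccccc3o2)c2nc(C#N)c(C#N)nc21`: 5470 nM
Compound 2 `CN(C)CCCCn1c(N)c(-c2nc3ccccc3s2)c2nc(C#N)c(C#N)nc21`: 35800 nM
Compound 3 `CN(C)CCn1c(N)c(-c2nc3cc(Cl)ccc3[nH]2)c2nc(C#N)c(C#N)nc21`: > 50000 nM

All three compounds were tested in a functional assay on A549 cells (Homo sapiens) for antiproliferative activity, read by MTT assay, with a stated time of 48 h; on this read-out higher numbers stand for weaker inhibition and lower numbers for stronger inhibition. Compound 3 gives only a limit, > 50000 nM, and not a number. Its standing on the numbers shown is the limit of > 50000 nM in this assay, at which 1 of the 3 values shown sits.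

Compound 4 `CN(C)CCCCn1c(N)c(-c2nc3cc(Cl)ccc3[nH]2)c2nc(C#N)c(C#N)nc21` keeps the rest of compound 3 and changes only the chain: 2-(dimethylamino)ethyl in place of dimethylamino on a saturated chain carbon, two bonds along the chain from an aromatic nitrogen. In words, this is 2-(dimethylamino)ethyl in place of dimethylamino on a saturated chain carbon, two bonds along the chain from an aromatic nitrogen. Read one bond further out, 2-(dimethylamino)ethyl becomes 4-(dimethylamino)butyl.

Going by the values given here, no measured step changes this chain, so its size cannot be read directly. Among the compounds with values here, the only measured step, a 6.5-fold higher number from compound 1 to compound 2 (0.82 log units; beyond the scatter), swaps a different group while the 4-(dimethylamino)butyl chain stays in place. It shows how far the number can move with that chain present. With this chain, compound 1 gives 5470 nM and compound 2 gives 35800 nM. Both lack the group shared by compound 3 and compound 4, so they are only a rough guide. A lower number, meaning stronger inhibition, is therefore expected in this assay, in the region of those two values.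

For compound 4 the estimated value is 12000 nM, with an expected range from 3000 nM to 45000 nM. The expected change is an at least 4.1-fold lower number from compound 3 to compound 4 (0.61 log units; beyond the scatter). It starts from a limit, so it is only approximate.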

Compound 4, half-maximal inhibitory concentration: 12100 nM
The estimate for compound 4 lay 1.0-fold (0.00 log units) below the measured number, within the range that was stated.
By their numbers in this assay, from the lowest: compound 1; then compound 4; then compound 2. At a limit, above all of these: compound 3.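

Going by these compounds alone, the chain change gives an at least 4.1-fold lower number from compound 3 to compound 4 (0.61 log units; beyond the scatter), the first measured step at this position, so in this assay the number moves with the chain when the 5-chloro-1H-benzimidazol-2-yl group is present. Compound 3 gives only a limit, so this step has a minimum size and no exact one: the limit of > 50000 nM in this assay, at which 1 of the 4 values shown sits.

With the 4-(dimethylamino)butyl chain held constant, the three groups on the aromatic carbon can now be compared, and 5-chloro-1H-benzimidazol-2-yl gives a 3.0-fold lower number from compound 2 to compound 4 (0.47 log units; beyond the scatter) against 1,3-benzothiazol-2-yl, and a 2.2-fold higher number from compound 1 to compound 4 (0.34 log units; beyond the scatter) against 1,3-benzoxazol-2-yl.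

The compounds shown cover only two chain lengths, so it remains open how a 3-(dimethylamino)propyl chain, a chain longer than 4-(dimethylamino)butyl, or a chain ending in a morpholine would compare with compound 4. Going by these compounds, it is also open whether shortening the chain to 2-(dimethylamino)ethyl would move the number in the same direction with the 1,3-benzoxazol-2-yl group of compound 1 as it does with the 5-chloro-1H-benzimidazol-2-yl group.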